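Methoxy for fluoro on the outer aryl ring

The compounds below may be only part of what the source reports. "The series", "measured", "known", "first", "only" and "open" are said of these compounds alone.

Compound 3 `O=[N+]([O-])c1ccc(CN2CCC(n3cc(CC(OCc4cc(-c5cccc(F)c5)no4)c4ccc(Br)cc4)nn3)CC2)cc1` gives 3000 nM in a functional assay on MDA-MB-468 cells (Homo sapiens) for cytotoxicity, with a stated time of 48 h; a lower number here means a stronger inhibitor, a higher number a weaker inhibitor. For the measured compounds named here, it stands level with compound 1 `O=[N+]([O-])c1ccc(CN2CCC(n3cc(CC(OCc4cc(-c5ccccc5)no4)c4ccc(Br)cc4)nn3)CC2)cc1`, which gives 3000 nM, and the two share the lowest number of the three measured so far; compound 2 `COc1ccc(-c2cc(COC(Cc3cn(C4CCN(Cc5ccc([N+](=O)[O-])cc5)CC4)nn3)c3ccc(Br)cc3)on2)cc1` gives 9000 nM in this assay. The measured steps read: a 3.0-fold higher number from compound 1 to compound 2 (0.48 log units; beyond the scatter); no change at the digits printed from compound 1 to compound 3 (within the scatter); and a 3.0-fold lower number from compound 2 to compound 3 (0.48 log units; beyond the scatter).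

Compound 4 `COc1cccc(-c2cc(COC(Cc3cn(C4CCN(Cc5ccc([N+](=O)[O-])cc5)CC4)nn3)c3ccc(Br)cc3)on2)c1` differs from compound 3 in one place: methoxy in place of fluoro on an aromatic carbon. Going by the values given here, two measured steps bear on this. The first, a 3.0-fold higher number from compound 1 to compound 2 (0.48 log units; beyond the scatter), is the only one in which a methoxy group enters, and it went to a higher number. The second, no change at the digits printed from compound 1 to compound 3 (within the scatter), shows the fluoro that now leaves made no difference against hydrogen, so removing it should not on its own move the number. Among the compounds with values here, no measured pair places a methoxy group where compound 4 carries it, so whether the rise seen with compound 2 transfers is unknown. Within the data shown here, a modest rise is nonetheless the more likely outcome, and the estimated step is a 1.7-fold higher number from compound 3 to compound 4 (0.22 log units; within the scatter), smaller than the one seen with compound 2. Compound 4 is therefore expected at about 5000 nM, in a range from 2500 nM to 12000 nM.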

Compound 4, half-maximal inhibitory concentration: > 25000 nM
Compound 4: a limit, no number; the forecaster's own chance of this, stated with the estimate: 5%; middle value at least 5.0-fold (0.69 log units) from the limit.
By their numbers in this assay, from the lowest: compounds 1 and 3 (each within the scatter of the next); then compound 2. At a limit, above all of these: compound 4.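

In this assay compound 4 gives > 25000 nM, which is a limit of the assay and not a number. For the compounds shown here, on the six-membered aromatic ring, at the carbon meta to a large group, methoxy separates clearly from both fluoro and hydrogen, with an at least 8.3-fold higher number from compound 3 to compound 4 (0.92 log units; beyond the scatter) and an at least 8.3-fold higher number from compound 1 to compound 4 (0.92 log units; beyond the scatter), whereas fluoro and hydrogen could not be told apart in the earlier compounds. The place of the methoxy also counts, not only its presence: 3-methoxyphenyl in place of 4-methoxyphenyl gives an at least 2.7-fold higher number from compound 2 to compound 4 (0.44 log units; beyond the scatter), so the step seen earlier with 4-methoxyphenyl did not set the size of the change for 3-methoxyphenyl, and in the compounds shown both methoxy groups go with a higher number than hydrogen, with no compound against this.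

Going by these compounds, the true size of all three new steps stays open beyond what the limit allows, so they fix only a lower bound. Also open, on these data alone, is whether a hydroxy group, an amine or a chlorine at this same carbon would read like fluoro or like methoxy, and whether an ethoxy group would go further in the same direction.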